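The source may hold more compounds than are shown below. What is called first, only, known or untested is meant among the compounds shown, and "the series" means these compounds.

Of the compounds shown here, three of a shared core have been measured in a functional assay for antagonist activity at transient receptor potential cation channel subfamily V member 1 (Homo sapiens), read by FLIPR and calcium flux; a higher number here means a more potent compound, by a factor of ten per unit of this negative logarithm, a lower number a less potent compound. Compound 1 `CN1CCCc2ccc(NC(=O)c3ccc(-c4ccccc4)cc3)cc21` stands highest of the three numbers: in this assay compound 1 gives 7.5. Compound 2 `COCC(=O)N1CCCc2ccc(NC(=O)c3ccc(-c4ccccc4)cc3)cc21` carries a (methoxymethyl)carbonyl in place of the methyl on the ring nitrogen, and in this assay compound 2 gives 7.2, a change of a number 0.30 log units lower from compound 1 to compound 2 (within the scatter). Compound 3 `CN1CCCc2ccc(NC(=O)c3ccc(-c4ccccc4)cc3Cl)cc21` carries a chloro in place of a hydrogen on an aromatic carbon, and in this assay compound 3 gives 7.1, a change of a number 0.40 log units lower from compound 1 to compound 3 (beyond the scatter).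

Compound 4 `CN1CCCc2ccc(NC(=O)c3ccc(-c4cccs4)cc3)cc21` differs from compound 1 in a third place: thiophen-2-yl in place of phenyl on an aromatic carbon. Neither measured step touches this part of the molecule, so there is no direct guide to how the change will land. What the two steps do show is that single changes elsewhere on this core moved the number only a little and downward, one within the scatter and one modestly beyond it. The expectation is therefore a small step, most likely downward or none beyond the scatter, estimated as a number 0.20 log units lower from compound 1 to compound 4 (within the scatter). In this assay compound 4 is expected to give about 7.3, with a range from 6.8 to 7.8.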

Compound 4, negative logarithm of the antagonist equilibrium constant: 7.6
Compound 4: middle estimate off by 0.30 log units, on the low side; low and high end bracket the measured number.
By their numbers in this assay, from the lowest: compounds 3, 2, 1 and 4 (each within the scatter of the next, the first and the last beyond it).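

In this assay, among the compounds shown here, the step of a number 0.10 log units higher from compound 1 to compound 4 (within the scatter) is the first view of the outer ring, the group on an aromatic carbon para to a large group, which neither earlier step touched. The two compounds cannot be told apart here, so at this position the core of compound 1 accepts a five-membered aromatic ring with 1 hetero atom, a sulfur, in place of a six-membered aromatic ring of carbon only, even though the heavy atoms go from 6 to 5 and a hydrogen-bond acceptor is added. Nothing in the data shown explains why the number holds across this exchange.

From the compounds shown here alone, this single pair says nothing about how far that acceptance reaches, so it remains open whether thiophen-3-yl, a pyridine ring, a saturated ring such as cyclohexyl, or a group carrying an amine or a carboxylic acid would hold the number in the same place. Also open, going by these compounds, is whether thiophen-2-yl would behave the same alongside the chloro of compound 3 or the (methoxymethyl)carbonyl of compound 2.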